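The source may report more compounds than this note shows. Statements on the series, on what has been measured and on what is new or still open speak of the compounds shown alone.

Compound 1 `CC(=O)Nc1[nH]nc2nnc(-c3ccccc3)c(-c3ccccc3)c12`: > 100000 nM, a limit of the assay and not a number
Compound 2 `O=C(Nc1ccccc1)Nc1[nH]nc2nnc(-c3ccccc3)c(-c3ccccc3)c12`: 2930 nM
Compound 3 `Nc1[nH]nc2nnc(-c3ccccc3-c3ccccc3)c(-c3ccccc3-c3ccccc3)c12`: 30700 nM

All three values come from a functional assay on HeLa cells (Homo sapiens) for cytotoxicity; on this read-out higher numbers stand for weaker inhibition and lower numbers for stronger inhibition. Of the two values that are true numbers, the lower belongs to compound 2, at 2930 nM. The other belongs to compound 3, at 30700 nM, a gap beyond the scatter.

Compound 4 `CCNC(=O)Nc1[nH]nc2nnc(-c3ccccc3)c(-c3ccccc3)c12` has not yet been measured. It differs from compound 2 in one place, with ethyl in place of phenyl on an amide-type nitrogen.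

For the measured compounds named here, only one measured step touches this part of the molecule, and it is an at least 34-fold lower number from compound 1 to compound 2 (1.53 log units; beyond the scatter). That change, anilino in place of methyl on a carbonyl carbon, was large, and its true size is open because the limit of > 100000 nM in this assay, at which 1 of the 3 values shown sits, applies to compound 1. It is only a partial guide, since compound 4 keeps the amide-type nitrogen that compound 1 lacks. Like compound 1, however, compound 4 has no phenyl at this place. A move toward higher numbers, and so weaker inhibition, therefore seems likely, covering part of the measured step and still beyond the scatter. The expected change is a 6.8-fold higher number from compound 2 to compound 4 (0.83 log units; beyond the scatter). In this assay the estimated value for compound 4 is 20000 nM, with an expected range of 4000 nM to 100000 nM.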

Compound 4, half-maximal inhibitory concentration: 60400 nM
The estimate for compound 4 lay 3.0-fold (0.48 log units) below the measured number, within the range that was stated.
By their numbers in this assay, from the lowest: compound 2; then compounds 3 and 4 (each within the scatter of the next). At a limit, above all of these: compound 1.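

In this assay, for the compounds shown here, the phenyl of compound 2 proves important in its own right: with the amide-type nitrogen kept and only that ring exchanged for ethyl, the result is a 21-fold higher number from compound 2 to compound 4 (1.31 log units; beyond the scatter), a large loss of inhibition. The nitrogen with a small ethyl on it shows no clear gain over the methyl of compound 1, since the step is an at least 1.6-fold lower number from compound 1 to compound 4 (0.21 log units; that floor lies within the scatter), so most of what separates compound 2 from compound 1 goes with the phenyl rather than with the added nitrogen alone. That reading remains tentative, and the true size of the step stays open because compound 1 stands at a limit of the assay and not at a number: the limit of > 100000 nM in this assay, at which 1 of the 4 values shown sits.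

The compounds shown cannot tell whether the aromatic ring itself counts or simply a larger group on this nitrogen, a question that cyclohexyl or a longer chain such as butyl would address. They also leave open how a phenyl carrying a chlorine or a methoxy group would compare with the plain phenyl of compound 2.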